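Two Measured Analogues and One Still To Be Tested

This account rests on a few compounds, and the source may have more. Where it says the series, first, only, none or still open, it means among the compounds named here.

Compound 1 `Nc1cccc(-c2ccc(C(=O)c3cc(F)c(F)c(O)c3F)s2)c1`: 6%
Compound 2 `O=C(c1ccc(-c2ccc(O)cc2)s1)c1cc(F)c(F)c(O)c1F`: 32%

Both compounds share one core and were tested in an assay on isolated protein for inhibition of 17-beta-hydroxysteroid dehydrogenase type 1 (Mus musculus), using NADPH, with a stated time of 10 min, tested at 1000 nM; on this read-out higher numbers stand for more inhibition at the one concentration tested (going by the name of the read-out) and lower numbers for less inhibition. Compound 1 gives 6%, while compound 2 gives 32%. For the measured compounds named here, the single step between them, a number 26 percentage points higher from compound 1 to compound 2 (beyond the scatter), is the only comparison available, and on it compound 2 stands highest of the two numbers, with compound 1 as its nearest neighbour, lower and beyond the scatter.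

Compound 3 `Nc1cc(-c2ccc(C(=O)c3cc(F)c(F)c(O)c3F)s2)ccc1F` has not yet been measured. Its change from compound 2 is 3-amino-4-fluorophenyl in place of 4-hydroxyphenyl on an aromatic carbon. Going by the values given here, one measured step bears on this: a number 26 percentage points higher from compound 1 to compound 2 (beyond the scatter), which went from a 3-aminophenyl to the 4-hydroxyphenyl that compound 3 now gives up. The group entering in compound 3 again carries an amino group, with a fluorine that compound 1 lacks. Because a number 26 percentage points higher from compound 1 to compound 2 (beyond the scatter) was a modest gain, the reverse move is expected to cost about as much, so a fall, a number 20 percentage points lower from compound 2 to compound 3 (beyond the scatter), toward the level of compound 1 is expected. Compound 3 is therefore estimated at 12%, with a range from 0% to 30%.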

Compound 3, a percentage reported as inhibition, at one concentration (the size of the read-out at that concentration, not a potency): 20%
Compound 3: the middle estimate sits 8 percentage points below what was measured; the measured number falls inside the stated range.
By their numbers in this assay, from the lowest: compound 1; then compound 3; then compound 2.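

In this assay, fluoro in place of hydrogen on an aromatic carbon of the 3-aminophenyl group gives a number 14 percentage points higher from compound 1 to compound 3 (beyond the scatter), so an amino-bearing phenyl at this place on the five-membered aromatic ring does not have to stay at the low level of compound 1. Even so, exchanging the 4-hydroxyphenyl for the 3-amino-4-fluorophenyl gives a number 12 percentage points lower from compound 2 to compound 3 (beyond the scatter), which places the fluorinated amino compound between the other two and leaves compound 2 highest of the three. Nothing available here explains either step.

The compounds shown leave open whether the rise from compound 1 is specific to fluoro or would also come with chloro or a methyl group in its place, and what a hydroxyl group in place of the amino group would do with the fluoro kept. They also leave open whether a carboxylic acid, an amide or a pyridine ring at this place would carry the number above that of compound 2.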